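The source may report more compounds than this note shows. Statements on the series, on what has been measured and on what is new or still open speak of the compounds shown alone.

Compound 1 `C=CS(=O)(=O)N1CCN(c2ncnc3sc(-c4cn(S(=O)(=O)c5ccccc5)c5ccccc45)cc23)CC1`: 40400 nM
Compound 2 `CN1CCN(c2ccc(-c3cc4c(N5CCN(S(=O)(=O)N6CCCCC6)CC5)ncnc4s3)cc2)CC1`: 8130 nM

These two compounds have been tested in a functional assay on MDA-MB-231 cells (Homo sapiens) for antiproliferative activity, read by MTT assay, with a stated time of 48 h; on this read-out higher numbers stand for weaker inhibition and lower numbers for stronger inhibition. Compound 2 has the lower number of the pair, and its gap to compound 1 lies beyond the usual scatter, so compound 2 is the better starting point. The next compound, compound 3 `CN1CCN(c2ccc(-c3cc4c(N5CCN(C(=O)Nc6ccccc6F)CC5)ncnc4s3)cc2)CC1`, keeps everything in compound 2 except one group: (2-fluorophenyl)carbamoyl comes in place of (piperidin-1-yl)sulfonyl on an amine nitrogen in a ring ((2-fluorophenyl)carbamoyl in place of (piperidin-1-yl)sulfonyl on an amine nitrogen in a ring). Going by the values given here, no measured pair shows what this swap does, since compounds 1 and 2 differ in more than one place. The expectation therefore stays close to compound 2 at 8130 nM, with a modest move toward stronger inhibition. The estimated change is a 1.6-fold lower number from compound 2 to compound 3 (0.21 log units; within the scatter). For compound 3 the estimated value is 5000 nM, with an expected range from 1200 nM to 20000 nM.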

Compound 3, half-maximal inhibitory concentration: 10300 nM
Compound 3: the middle estimate sits 2.1-fold (0.31 log units) below what was measured; the range from low to high includes it.
By their numbers in this assay, from the lowest: compounds 2 and 3 (each within the scatter of the next); then compound 1.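

Going by these compounds alone, on an amine nitrogen in a ring, (2-fluorophenyl)carbamoyl in place of (piperidin-1-yl)sulfonyl gives a 1.3-fold higher number from compound 2 to compound 3 (0.10 log units; within the scatter) in this assay, the first step here that differs in one place only. The two groups are quite different: the one that leaves holds a six-membered non-aromatic ring and a sulfur, while the one that enters holds a six-membered aromatic ring of carbon only and a hydrogen-bond donor. Even so, compound 2 and compound 3 cannot be told apart in this read-out, so this pair shows that the swap leaves the antiproliferative number within the usual scatter.

Still open, on these data alone, is whether a much smaller group on that nitrogen, such as acetyl or methyl, would behave the same way. A plain phenylcarbamoyl would show whether the fluorine matters at all, and nothing available offers an explanation for this result.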